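This account rests on a few compounds, and the source may have more. Where it says the series, first, only, none or still open, it means among the compounds named here.

Measured compounds in a functional assay on DU-145 cells (Homo sapiens) for inhibition, read by trypan blue exclusion, with a stated time of 96 h; a lower number here means a stronger inhibitor of growth, a higher number a weaker inhibitor of growth:
Compound 1 `Cc1ccc(CS/C(=C/c2ccc(N(C)C)cc2)C(=O)c2ccc(Cl)cc2)cc1` gives > 100000 nM, a limit of the assay rather than a number.
Compound 2 `Cc1ccc(CS/C(=C/c2c[nH]c3ccc(Cl)cc23)C(=O)c2ccc(Cl)cc2)cc1` gives 1000 nM.
Compound 3 `CC(=O)Oc1ccc(/C=C(\C(=O)c2ccc(Cl)cc2)S(=O)(=O)c2ccc(C)cc2)cc1` gives 25000 nM.

Compound 2 holds the lowest of the two numbers in this assay; compound 3 sits at a higher number, beyond the scatter. Compound 1 returns only a limit, (the limit of > 100000 nM in this assay, at which 1 of the 3 values shown sits). Among the compounds with values here, the single measured step at the place in question, an at least 100-fold lower number from compound 1 to compound 2 (2.00 log units; beyond the scatter), is large: 5-chloro-1H-indol-3-yl in place of 4-(dimethylamino)phenyl on a double-bonded chain carbon bound to a double-bonded chain carbon takes the number from the limit down to the lowest value in the set.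

Compound 4 `COc1ccccc1/C=C(/SCc1ccc(C)cc1)C(=O)c1ccc(Cl)cc1` is not yet measured. Against compound 2 the change is 2-methoxyphenyl in place of 5-chloro-1H-indol-3-yl on a double-bonded chain carbon bound to a double-bonded chain carbon. The 5-chloro-1H-indol-3-yl group that marked the large drop of an at least 100-fold lower number from compound 1 to compound 2 (2.00 log units; beyond the scatter) is removed, and a six-membered aromatic ring of carbon only enters in its stead; compound 1 and compound 3, which each carry such a ring at that place, give the two weakest results shown. A large rise in the number is therefore expected for a 30-fold higher number from compound 2 to compound 4 (1.48 log units; beyond the scatter), with a fair chance that only a limit comes back. Compound 4 is estimated at 30000 nM, with a range from 5000 nM to 150000 nM.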

Compound 4, concentration for 50% growth inhibition: 10000 nM
Compound 4: middle estimate off by 3.0-fold (0.48 log units), on the high side; the range from low to high includes it.
By their numbers in this assay, from the lowest: compound 2; then compound 4; then compound 3. At a limit, above all of these: compound 1.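

With 2-methoxyphenyl in place of 4-(dimethylamino)phenyl on a double-bonded chain carbon bound to a double-bonded chain carbon, this assay shows an at least 10-fold lower number from compound 1 to compound 4 (1.00 log units; beyond the scatter), so a six-membered aromatic ring of carbon only at this place does not by itself settle the outcome. Compound 1 stands at a limit, not a number, and this step is therefore only a bound: the limit of > 100000 nM in this assay, at which 1 of the 4 values shown sits.

The 5-chloro-1H-indol-3-yl group still gives the lowest number, since its replacement brings a 10-fold higher number from compound 2 to compound 4 (1.00 log units; beyond the scatter), a modest step set against the large bound that compound 1 alone had suggested for this group.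

Which part of 5-chloro-1H-indol-3-yl carries this difference stays open: the chlorine, the ring nitrogen with its hydrogen, or the second ring; an indol-3-yl without the chlorine would begin to separate these. From the compounds shown here alone, how much of the gap between compound 1 and compound 4 belongs to the methoxy group and how much to the dimethylamino group also stays open, and a plain phenyl at this place would give the missing reference.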